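Amine ring variation on the shared core

The source may hold more compounds than are shown below. What is called first, only, known or untested is meant among the compounds shown, and "the series" means these compounds.

The series varies the cyclic amine attached to the shared core of compound 1 `O=C(CCc1ccc(C(F)(F)F)cc1)Nc1ccc2nc(N3CCCCC3)ccc2c1` while the amide side chain stays the same. In an assay on isolated protein for displacement of a labelled ligand from melanin-concentrating hormone receptor 1 (Homo sapiens) (on this read-out higher numbers stand for weaker inhibition and lower numbers for stronger inhibition), compound 1 gives 12 nM. Compound 2 `NC1CCN(c2ccc3cc(NC(=O)CCc4ccc(C(F)(F)F)cc4)ccc3n2)C1` gives 12 nM in this assay, and compound 3 `O=C(CCc1ccc(C(F)(F)F)cc1)Nc1ccc2nc(N3CCCCCC3)ccc2c1` gives 36 nM. Compound 1 thus stands level with compound 2, the two together the lowest of the three numbers. Between them the step is no change at the digits printed from compound 1 to compound 2 (within the scatter). Going by the values given here, the only step beyond the scatter is a 3.0-fold higher number from compound 1 to compound 3 (0.48 log units; beyond the scatter), and a 3.0-fold higher number from compound 2 to compound 3 (0.48 log units; beyond the scatter) matches it.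

Compound 4 `CN(c1ccc2cc(NC(=O)CCc3ccc(C(F)(F)F)cc3)ccc2n1)C1CCCC1` is not yet measured. Its change from compound 1: cyclopentyl(methyl)amino in place of piperidin-1-yl on an aromatic carbon. Among the compounds with values here, two measured steps bear on this. The step of no change at the digits printed from compound 1 to compound 2 (within the scatter) shows one replacement of the piperidin-1-yl tolerated without change. The step of a 3.0-fold higher number from compound 1 to compound 3 (0.48 log units; beyond the scatter) shows another replacement costing a modest amount. Within the data shown here, no measured step replaces the ring amine by an open-chain one, so the direction rests on these two alone. The expected outcome for compound 4 is a step of a 1.7-fold higher number from compound 1 to compound 4 (0.22 log units; within the scatter) in this assay, small and possibly within the scatter. Compound 4 is estimated at 20 nM, with a range from 8 nM to 60 nM.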

Compound 4, half-maximal inhibitory concentration: 2 nM
Compound 4: middle estimate off by 10-fold (1.00 log units), on the high side; measured number outside the range, below it.
By their numbers in this assay, from the lowest: compound 4; then compounds 1 and 2 (each within the scatter of the next); then compound 3.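

In this assay, going by these compounds alone, the cyclopentyl(methyl)amino group on the aromatic carbon next to the ring nitrogen gives the only steps to a lower number: a 6.0-fold lower number from compound 1 to compound 4 (0.78 log units; beyond the scatter) and, of the same size, a 6.0-fold lower number from compound 2 to compound 4 (0.78 log units; beyond the scatter), while an 18-fold lower number from compound 3 to compound 4 (1.26 log units; beyond the scatter) is the largest step in the set. The earlier compounds shown here showed this position only holding level or losing ground, whereas compound 4 shows that a change here can also lower the number beyond the scatter, and does so with the amine nitrogen outside the ring rather than within it. No supporting measurement accounts for this gain, so it stands as an observation on these structures alone.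

From the compounds shown here alone, compound 4 carries the open-chain attachment, the methyl on the nitrogen and the cyclopentyl ring together, so the contribution of each remains open; dimethylamino, cyclopentylamino and cyclohexyl(methyl)amino at the same carbon would separate them. Also open, going by these compounds, is whether the gain persists when the amide side chain changes, for example to a longer chain or to one ending in a carboxylic acid.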